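Amino in place of chloro on the fused core

The source may hold more compounds than are shown below. What is called first, only, known or untested is meant among the compounds shown, and "the series" means these compounds.

Measured so far:
- compound 1, `Nc1nn(C(=O)Nc2ccc(Cc3ccccc3)cc2)c2ccccc12`: 27200 nM
- compound 2, `Nc1nn(C(=O)Nc2ccc(Cc3ccccc3)cc2)c2ccc(Cl)cc12`: 15600 nM

In a functional assay on TK-10 cells (Homo sapiens) for antiproliferative activity, read by sulforhodamine B assay, with a stated time of 48 h (a higher number here means a weaker inhibitor of growth, a lower number a stronger inhibitor of growth), compound 2 gives the lowest of the two numbers; its nearest neighbour is compound 1, and the step of a 1.7-fold lower number from compound 1 to compound 2 (0.24 log units; within the scatter) is within the scatter, so the two cannot be ordered. Compound 3, `Nc1ccc2c(c1)c(N)nn2C(=O)Nc1ccc(Cc2ccccc2)cc1`, differs from compound 2 by amino in place of chloro on an aromatic carbon. For the measured compounds named here, the only step measured at that carbon is a 1.7-fold lower number from compound 1 to compound 2 (0.24 log units; within the scatter), which shows no real movement; no measured step involves an amino group. The expectation for this assay is therefore no step beyond the scatter, a 1.3-fold higher number from compound 2 to compound 3 (0.11 log units; within the scatter). Compound 3 is estimated at 20000 nM, with a range of 7000 nM to 60000 nM.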

Compound 3, concentration for 50% growth inhibition: 19400 nM
Estimate against measurement, compound 3: 1.0-fold (0.01 log units) above, within the range that was stated.
By their numbers in this assay, from the lowest: compounds 2, 3 and 1 (each within the scatter of the next).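

In this assay, amino at this carbon brings a hydrogen-bond donor and acceptor that chloro lacks, yet the change stays within the scatter (a 1.2-fold higher number from compound 2 to compound 3 (0.09 log units; within the scatter)). Against hydrogen the reading is the same (a 1.4-fold lower number from compound 1 to compound 3 (0.15 log units; within the scatter)), so hydrogen, chloro and amino at this carbon cannot be ordered. Nothing available explains this flat result.

Going by these compounds, whether a carboxylic acid or a longer chain such as butoxy at this carbon would move the number beyond the scatter stays open. So does whether other carbons of the shared core respond differently.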